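The compounds below may be only part of what the source reports. "The series", "measured", "known", "first", "only" and "open" are said of these compounds alone.

Of the compounds shown here, two have numbers so far in an ADME assay on microsomes from liver (Homo sapiens) for metabolic stability, read by LC-MS, with a stated time of 30 min, tested at 1 uM (on this read-out higher numbers stand for a more stable compound and lower numbers for a less stable compound), and they differ in more than one place. Compound 1 `O=C(NCc1ccc(S(=O)(=O)c2cccc(F)c2)cc1)c1cc2cnccc2[nH]1` gives 79% and is the higher of the two. Compound 2 `O=C(NCc1ccc(S(=O)(=O)N2CCCCC2)cc1)c1ccc2nc[nH]c2c1` gives 53% which lies beyond the scatter from compound 1. That gap cannot be assigned to any single group. Compound 3 `O=C(NCc1ccc(S(=O)(=O)c2ccc(F)c(F)c2)cc1)c1cc2cnccc2[nH]1` keeps the core of compound 1 and changes one place in the sulfonyl aryl group: fluoro in place of hydrogen on an aromatic carbon is the whole difference, fluoro in place of hydrogen on an aromatic carbon, taking 3-fluorophenyl to 3,4-difluorophenyl. Among the measured compounds shown here, no measured pair shows this change, so the expectation starts from compound 1 at 79% and nothing more. Expected is a number 2 percentage points lower from compound 1 to compound 3 (within the scatter) as a step no larger than the scatter and without a firm direction. For compound 3 the estimated value is 77% with an expected range from 62% to 90% as the working estimate.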

Compound 3, percent of the compound remaining: 100%
Estimate against measurement, compound 3: 23 percentage points below; measured number outside the range, above it.
By their numbers in this assay, from the lowest: compound 2; then compound 1; then compound 3.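

In this assay, among the compounds shown here, fluoro in place of hydrogen on an aromatic carbon, taking 3-fluorophenyl to 3,4-difluorophenyl, gives a number 21 percentage points higher from compound 1 to compound 3 (beyond the scatter) and is the first change that can be read at a single place. This position, ortho to a fluoro group and para to a large group, therefore responds to one added fluorine on the core of compound 1, whereas the gap between the two earlier compounds could not be assigned to any single group. Nothing available bears on why the read-out moves at this position.

On these data alone, whether a chloro, methoxy or amino group at the same position would give a similar step remains open. Also open, as far as these compounds go, is whether the step carries over to any other core, because it rests on a single pair.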